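Swapping the acetamido on the pyrrole core for a cyclic imide

The source may hold more compounds than are shown below. What is called first, only, known or untested is meant among the compounds shown, and "the series" means these compounds.

Measured so far in a functional assay on HepG2 cells (Homo sapiens) for inhibition, read by sulforhodamine B assay, with a stated time of 24 h; on this read-out higher numbers stand for weaker inhibition and lower numbers for stronger inhibition:
compound 1 `N#Cc1c(-c2ccccc2)cn(-c2ccc(S(=O)(=O)Nc3nccs3)cc2)c1N` gives 5360 nM
compound 2 `CC(=O)Nc1c(C#N)c(-c2ccccc2)cn1-c1ccc(S(=O)(=O)Nc2nccs2)cc1` gives 4020 nM
compound 3 `CC(=O)Nc1c(C#N)c(-c2ccccc2)cn1-c1ccc(S(=O)(=O)Nc2ccccn2)cc1` gives 3490 nM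

Among these three, compound 2 has the second highest value; its neighbours are compound 3 at a 1.2-fold lower number from compound 2 to compound 3 (0.06 log units; within the scatter) and compound 1 at a 1.3-fold lower number from compound 1 to compound 2 (0.12 log units; within the scatter), so all three sit within the scatter of one another. Compound 4 `N#Cc1c(-c2ccccc2)cn(-c2ccc(S(=O)(=O)Nc3nccs3)cc2)c1N1C(=O)CCC1=O` changes compound 2 by 2,5-dioxopyrrolidin-1-yl in place of acetamido on an aromatic carbon. Among the compounds with values here, the only measured step at this carbon is the one from hydrogen to acetyl, a 1.3-fold lower number from compound 1 to compound 2 (0.12 log units; within the scatter), which was within the scatter. Compound 4 is therefore expected to show a step of a 1.0-fold lower number from compound 2 to compound 4 (0.00 log units; within the scatter), not beyond the scatter. The estimate for compound 4 in this assay is 4000 nM, with a range from 1500 nM to 10000 nM.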

Compound 4, half-maximal inhibitory concentration: 4560 nM
Compound 4: middle estimate off by 1.1-fold (0.06 log units), on the low side, within the range that was stated.
By their numbers in this assay, from the lowest: compounds 3, 2, 4 and 1 (each within the scatter of the next).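

In this assay, 2,5-dioxopyrrolidin-1-yl in place of acetamido gives a 1.1-fold higher number from compound 2 to compound 4 (0.05 log units; within the scatter) and in place of amino gives a 1.2-fold lower number from compound 1 to compound 4 (0.07 log units; within the scatter) on this same aromatic carbon. So a ring larger than acetamido, with no hydrogen-bond donors, still stays within the scatter of both earlier groups. Nothing available explains this flat result. The compounds shown leave open whether any group here, such as a carboxylic acid or a longer chain, would move the number beyond the scatter. From the compounds shown here alone, whether the imide behaves alike with pyridin-2-yl on the sulfonamide nitrogen also stays open.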